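Trifluoromethyl for Fluoro on a Biaryl Dichloroacetamide

The compounds below may be only part of what the source reports. "The series", "measured", "known", "first", "only" and "open" are said of these compounds alone.

Compound 1 `O=C(Nc1cccc(-c2cccc(F)c2)c1)C(Cl)Cl` carries a fluoro on the outer ring of its biaryl dichloroacetamide. In a functional assay on KB 3-1 cells (Homo sapiens) for cytotoxicity, read by MTT assay, with a stated time of 68 h (on this read-out higher numbers stand for weaker inhibition and lower numbers for stronger inhibition), compound 1 gives a limit of the assay, > 50000 nM. Compound 2 `O=C(Nc1cccc(-c2cccc(C(F)(F)F)c2)c1)C(Cl)Cl` differs from it by trifluoromethyl in place of fluoro on an aromatic carbon. In this assay compound 2 likewise gives only a limit, > 50000 nM. The step that the two limits leave unreadable from compound 1 to compound 2 is therefore unreadable, because of the limit of > 50000 nM in this assay, at which 2 of the 3 values shown sit. Compound 3 `O=C(Nc1cccc(-c2ccc(F)cc2)c1)C(Cl)Cl` has the same atoms as compound 1 joined differently; the difference between the two cores is not broken down here. In this assay, within the data shown here, compound 3 gives 26200 nM, the only number among the three. Compound 4 `O=C(Nc1cccc(-c2ccc(C(F)(F)F)cc2)c1)C(Cl)Cl` differs from compound 3 by trifluoromethyl in place of fluoro on an aromatic carbon, the same kind of change as that from compound 1 to compound 2, here para to a large group rather than meta to it. Since the earlier step is unreadable, the expected step of a 1.3-fold higher number from compound 3 to compound 4 (0.13 log units; within the scatter) rests only on the value of compound 3, 26200 nM, and is assumed small. Compound 4 is estimated at 35000 nM, between 12000 nM and 100000 nM.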

Compound 4, half-maximal inhibitory concentration: > 50000 nM
Compound 4 was reported as a limit (the forecaster's own chance of this, stated with the estimate: 45%); at least 1.4-fold (0.15 log units) between middle value and limit.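

Trifluoromethyl in place of fluoro on the core of compound 3 gives an at least 1.9-fold higher number from compound 3 to compound 4 (0.28 log units; that floor lies within the scatter) in this assay, so only a floor can be read, and that floor does not go beyond the usual scatter. The same change on the core of compound 1 cannot be read, and neither the size of the step on either core nor any match between the two can be fixed because so many values are limits: the limit of > 50000 nM in this assay, at which 3 of the 4 values shown sit.

What the series does show is narrow: compound 2 and compound 4, the two trifluoromethyl compounds, both give only a limit, so the change gives no number on either core, and carrying it from one core to the other is neither confirmed nor ruled out.

The compounds shown leave open how an amine or a carboxylic acid in place of fluoro on the outer ring would stand in this assay. They also leave open whether any replacement of fluoro on the core of compound 3 gives a lower number than compound 3 does.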